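The source may hold more compounds than are shown below. What is called first, only, known or untested is meant among the compounds shown, and "the series" means these compounds.

Measured so far in an assay on HEK293 cells for displacement of a labelled ligand from Melanocortin receptor 4 (Homo sapiens); on this read-out higher numbers stand for weaker inhibition and lower numbers for stronger inhibition:
compound 1, `CC(C)C[C@H](N)c1ccccc1N1CCN(C(=O)[C@H](C)Cc2ccc(Cl)cc2F)CC1`, 67 nM
compound 2, `COc1cc(CC(C)C(=O)N2CCN(c3ccc(C(F)(F)F)cc3[C@@H](N)CC(C)C)CC2)ccc1Cl`, 230 nM
compound 3, `CC(C)C[C@H](N)c1cc(C(F)(F)F)ccc1N1CCN(C(=O)COc2cccc(Cl)c2Cl)CC1`, 2500 nM

Compound 2 stands second highest of these three numbers. Its nearest neighbour is compound 1, whose number is lower and beyond the scatter of compound 2; its furthest is compound 3, reached by an 11-fold higher number from compound 2 to compound 3 (1.04 log units; beyond the scatter), a large step upward.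

Compound 4, `CC(C)C[C@H](N)c1cc(C(F)(F)F)ccc1N1CCN(C(=O)COc2ccc([N+](=O)[O-])cc2)CC1`, has not yet been measured. From compound 2 it differs in one place: (4-nitrophenoxy)methyl in place of 1-(4-chloro-3-methoxybenzyl)ethyl on a carbonyl carbon

Among the measured compounds shown here, the one measured step that bears on this change is the step from compound 2 to compound 3, since both changes replace the same group on the same carbonyl carbon with a substituted phenoxymethyl; that step was an 11-fold higher number from compound 2 to compound 3 (1.04 log units; beyond the scatter). The substitution on the entering ring differs, a nitro group in place of two chlorines, and nothing measured here separates these two patterns. The expectation is therefore a step of the same kind, large and upward in this assay, with wide uncertainty about its exact size.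

Compound 4 is thus expected to give about 2000 nM in this assay, within the range 600 nM to 6000 nM. This estimate corresponds to an expected step of an 8.7-fold higher number from compound 2 to compound 4 (0.94 log units; beyond the scatter).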

Compound 4, inhibition constant: 3100 nM
Beside the measured number, compound 4's estimate is 1.6-fold (0.19 log units) below it, within the range that was stated.
By their numbers in this assay, from the lowest: compound 1; then compound 2; then compounds 3 and 4 (each within the scatter of the next).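

In this assay, a second substituted phenoxymethyl group on this carbonyl carbon gives a large step of the same direction: a 13-fold higher number from compound 2 to compound 4 (1.13 log units; beyond the scatter), set against an 11-fold higher number from compound 2 to compound 3 (1.04 log units; beyond the scatter). The large step therefore does not belong to the 2,3-dichlorophenyl pattern alone, and exchanging that ring for 4-nitrophenyl on the oxygen on a saturated carbon gives a 1.2-fold higher number from compound 3 to compound 4 (0.09 log units; within the scatter), so these two ring patterns are not told apart in this assay. Nothing measured here explains either the large step or the absence of a separation between the two rings.

The (4-nitrophenoxy)methyl and (2,3-dichlorophenoxy)methyl groups both differ from 1-(4-chloro-3-methoxybenzyl)ethyl in more than one feature, so the compounds shown do not say which part of the exchange carries the step. Also open, as far as these compounds go, is whether a phenoxymethyl group carrying an amine or a carboxylic acid in place of the nitro group, or a longer chain in place of the methyl part of the group, would stay at this level or return towards compound 2 at 230 nM.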